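The source may report more compounds than this note shows. Statements on the series, on what has been measured and on what is new or still open speak of the compounds shown alone.

Measured so far in a functional assay on the whole organism (strain Hartley) for inhibition, with Cavia porcellus as the target, with stated times of 2 min and 15 min (on this read-out lower numbers stand for an effect already at smaller amounts and higher numbers for an effect only at larger amounts of compound), are three compounds:
- compound 1 `CCCCC[C@H](O)/C=C/C1CCC(=O)[C@@H]1CCCCSCC(=O)O` at 0.00129 mg/kg
- compound 2 `CCCCC[C@@H](O)/C=C/C1CCC(=O)[C@@H]1CCCCSCC(=O)O` at 0.0233 mg/kg
- compound 3 `CCCCC(C)(C)[C@H](O)/C=C/C1CCC(=O)[C@@H]1CCCCSCC(=O)O` at 0.0523 mg/kg

Compound 3 has the highest number of the three, and compound 2 lies closest to it, while compound 1 lies furthest away. Compound 4 `CCCCC(C)(C)[C@@H](O)/C=C/C1CCC(=O)[C@@H]1CCCCSCC(=O)O` is the untested partner of compound 3 (the difference: the two compounds have the same atoms and bonds; at least one stereo element is drawn with a configuration in one of them and without one in the other: 1 of 4 stereo elements differ; a stereocentre at a saturated chain carbon is drawn R in compound 3 and S in compound 4). The letters R and S alone mislead here. Compound 3 is drawn with the same spatial arrangement at this centre as compound 1, and compound 4 with the same arrangement as compound 2.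

Within the data shown here, the closest precedent is therefore the measured inversion, which gave an 18-fold higher number from compound 1 to compound 2 (1.26 log units; beyond the scatter) and was large. The other measured step, a 41-fold higher number from compound 1 to compound 3 (1.61 log units; beyond the scatter), is also large and shows that compound 3 already starts from a much higher number. A single precedent in a different chain cannot fix the size, and the inversion may cost somewhat less here. A large step towards a higher number is still expected in this assay, estimated as a 9.6-fold higher number from compound 3 to compound 4 (0.98 log units; beyond the scatter) overall. For compound 4 the expected value is 0.5 mg/kg, with an estimated range from 0.12 mg/kg to 2.5 mg/kg.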

Compound 4, dose for half-maximal effect: 0.032 mg/kg
Compound 4: the middle estimate sits 16-fold (1.19 log units) above what was measured; the whole stated range lies above it.
By their numbers in this assay, from the lowest: compound 1; then compounds 2, 4 and 3 (each within the scatter of the next, the first and the last beyond it).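

In this assay, among these compounds, the inversion at the saturated chain carbon no longer separates the pair carrying 1,1-dimethylpentyl: the step is a 1.6-fold lower number from compound 3 to compound 4 (0.21 log units; within the scatter), whereas on the pentyl pair the inversion of the same arrangement gave an 18-fold higher number from compound 1 to compound 2 (1.26 log units; beyond the scatter). The exchange of pentyl for 1,1-dimethylpentyl therefore depends on the arrangement at this centre, with a 1.4-fold higher number from compound 2 to compound 4 (0.14 log units; within the scatter) set against a 41-fold higher number from compound 1 to compound 3 (1.61 log units; beyond the scatter). The inversion and the exchange thus do not act independently of each other, and the exchange has no single size in this small set: the same change on two cores in this assay, a 41-fold higher number (1.61 log units; beyond the scatter) from compound 1 to compound 3 and a 1.4-fold higher number (0.14 log units; within the scatter) from compound 2 to compound 4, 30-fold (1.47 log units) apart, beyond the scatter of two such steps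

The four compounds leave open whether the strong dependence on the arrangement seen with pentyl would persist with 1-methylpentyl or hexyl in its place, and so how much of the chain change is needed to remove it. They also leave open whether the same interplay would appear with a phenoxy group at the end of the chain, and a whole-organism read-out of this kind does not by itself say at which stage the two arrangements part.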